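The source may hold more compounds than are shown below. What is called first, only, known or untested is meant among the compounds shown, and "the series" means these compounds.

Working notes on the series. Compound 1 `COc1ccc(-c2csc(N3N=C(c4ccc(C)cc4)CC3c3ccc4c(c3)OCCO4)n2)cc1` is the reference point: in a functional assay on B16-F10 cells (Mus musculus) for antiproliferative activity, read by MTT assay, with a stated time of 48 h (a higher number here means a weaker inhibitor, a lower number a stronger inhibitor), compound 1 gives 2870 nM. Compound 2 `COc1ccc(-c2csc(N3N=C(c4ccc(F)cc4)CC3c3ccc4c(c3)OCCO4)n2)cc1` keeps the whole framework and differs only in one aromatic substituent; in this assay compound 2 gives 4430 nM. Among the measured compounds shown here, the one measured step, a 1.5-fold higher number from compound 1 to compound 2 (0.19 log units; within the scatter), is small and leaves the two compounds indistinguishable on the numbers at hand. For the measured compounds named here, compound 2 thus holds the higher of the two numbers, with compound 1 the only neighbour and within the scatter of it.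

The next compound, compound 3 `Fc1ccc(C2=NN(c3nc(-c4ccc(Br)cc4)cs3)C(c3ccc4c(c3)OCCO4)C2)cc1`, starts from compound 2 and carries the change (bromo in place of methoxy on an aromatic carbon). Going by the values given here, no measured step touches this position: the single step recorded, from compound 1 to compound 2, alters a different ring and is itself within the scatter, so it gives no guide to the size or direction of an exchange at this site. With nothing to anchor a shift, the number for compound 3 in this assay is expected to stay near that of compound 2, a step of a 1.1-fold lower number from compound 2 to compound 3 (0.04 log units; within the scatter), with wide uncertainty. The estimate for compound 3 is therefore 4000 nM, expected to fall between 1400 nM and 12000 nM.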

Compound 3, half-maximal inhibitory concentration: 4110 nM
Compound 3: middle estimate off by 1.0-fold (0.01 log units), on the low side, within the range that was stated.
By their numbers in this assay, from the lowest: compounds 1, 3 and 2 (each within the scatter of the next).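

In this assay, the exchange of 4-methoxyphenyl for 4-bromophenyl, on the aromatic carbon para to a large group, gives a 1.1-fold lower number from compound 2 to compound 3 (0.03 log units; within the scatter), so this position now has a measured step of its own and the two compounds cannot be told apart. Methoxy, with 2 heavy atoms and 1 hydrogen-bond acceptor, gives way to bromo, with 1 heavy atom and 0 hydrogen-bond acceptors, and this difference produces no separation beyond the scatter, as with the step at the other ring, a 1.5-fold higher number from compound 1 to compound 2 (0.19 log units; within the scatter). No measurement is at hand that would explain the numbers at this position.

The compounds shown leave open how an amine, a carboxylic acid or a longer chain on this aromatic carbon would read in this assay, as methoxy and bromo are the only groups seen here. Also open, going by these compounds, is whether bromo would read the same alongside the methyl of compound 1 as it does alongside the fluoro of compound 3.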